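Carbinol in place of the fluorophenylsulfonyl group

The compounds below may be only part of what the source reports. "The series", "measured", "known", "first", "only" and "open" are said of these compounds alone.

Of the compounds shown here, two of the shared core have been measured. Compound 1 `Cc1c(Cc2ccccc2S(=O)(=O)c2ccccc2F)c2c(n1CC(=O)O)CCNC2=O` gives 3.6 nM in a functional assay on CHO.K1 cells for antagonist activity at prostaglandin D2 receptor 2 (Homo sapiens), read by GTPgammaS binding, with a stated time of 1 h; a higher number here means a weaker inhibitor, a lower number a stronger inhibitor; compound 2 `COc1ccc(S(=O)(=O)c2ccc(F)cc2)c(Cc2c3c(n(CC(=O)O)c2C)CCNC3=O)c1` gives 7.1 nM in this assay, and the two values fall within the usual scatter of each other. Compound 3 `Cc1c(Cc2ccccc2C(O)c2ccccc2)c2c(n1CC(=O)O)CCNC2=O` carries the change hydroxy(phenyl)methyl in place of (2-fluorophenyl)sulfonyl on an aromatic carbon relative to compound 1. For the measured compounds named here, no measured pair shows this change, so the step from compound 1 to compound 3 is expected as a 4.2-fold higher number from compound 1 to compound 3 (0.62 log units; beyond the scatter), a moderate weakening. Compound 3 is therefore estimated at 15 nM in this assay, with a range of 4 nM to 60 nM.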

Compound 3, half-maximal inhibitory concentration: 32 nM
Beside the measured number, compound 3's estimate is 2.1-fold (0.33 log units) below it; low and high end bracket the measured number.
By their numbers in this assay, from the lowest: compounds 1 and 2 (each within the scatter of the next); then compound 3.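

Swapping (2-fluorophenyl)sulfonyl for hydroxy(phenyl)methyl on this aromatic carbon gives an 8.9-fold higher number from compound 1 to compound 3 (0.95 log units; beyond the scatter) in this assay, a step beyond the scatter. The position therefore responds to the group it carries, although compound 3 still gives 32 nM with the carbinol in place. No available evidence accounts for this loss.

Open, on these data alone, is whether a ketone carbonyl or an amine in place of the carbinol hydroxy would give a value nearer that of compound 1 or of compound 3. Also open, as far as these compounds go, is what a 2-fluorophenyl ring on the carbinol carbon would do.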